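The compounds below may be only part of what the source reports. "The series", "measured", "known", "first", "only" and "open" are said of these compounds alone.

Measured compounds:
compound 1, `CC(C)=C1C(=O)N(c2ccc(Cl)cc2)N(c2ccc(Cl)cc2)C1=O`, 42100 nM
compound 2, `COc1cc(C=C2C(=O)N(c3ccc(Cl)cc3)N(c3ccc(Cl)cc3)C2=O)cc(OC)c1OC`, 10100 nM
compound 3, `O=C1C(=Cc2cccc(Cl)c2)C(=O)N(c2ccc(Cl)cc2)N1c1ccc(Cl)cc1`, 22600 nM

All three share one core, a ring bearing two chlorophenyl groups, and differ only in the group attached to it by a double bond. In a functional assay on ECa-109 cells (Homo sapiens) for cytotoxicity, read by MTT assay, with a stated time of 72 h (a higher number here means a weaker inhibitor, a lower number a stronger inhibitor), compound 1 gives 42100 nM, compound 2 gives 10100 nM, and compound 3 gives 22600 nM. Compound 3 has the second highest of these three numbers. Its nearest neighbour is compound 1, whose number is close enough that the two cannot be told apart by a single measurement. Compound 2 gives a clearly lower number than compound 3, so compound 2 is the stronger inhibitor of that pair.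

Compound 4, `O=C1C(=Cc2ccccc2)C(=O)N(c2ccc(Cl)cc2)N1c1ccc(Cl)cc1`, has not yet been measured in this assay. It differs from compound 3 in one place: hydrogen in place of chloro on an aromatic carbon. The chloro leaves and a hydrogen takes its spot, so the ring on the double bond becomes a plain phenyl. Going by the values given here, with no measured step of this exact kind among the compounds, the expectation for compound 4 rests on how little is removed. Compound 4 is expected to give a number much like that of compound 3, perhaps slightly higher, so the step of a 1.2-fold higher number from compound 3 to compound 4 (0.09 log units; within the scatter) is estimated to stay within the scatter. Compound 4 is estimated at 28000 nM, with a range from 12000 nM to 65000 nM.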

Compound 4, half-maximal inhibitory concentration: 32700 nM
Estimate against measurement, compound 4: 1.2-fold (0.07 log units) below; low and high end bracket the measured number.
By their numbers in this assay, from the lowest: compound 2; then compounds 3, 4 and 1 (each within the scatter of the next).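

Swapping chloro for hydrogen on an aromatic carbon of the ring on the double bond, which turns 3-chlorophenyl into phenyl, gives a 1.4-fold higher number from compound 3 to compound 4 (0.16 log units; within the scatter) in this assay. Going by these compounds alone, this is the first comparison here in which only one atom differs, as the earlier compounds differ from each other by whole groups, and it shows that compound 3 and compound 4 cannot be told apart by this read-out. At this position, then, the chloro is not needed for the activity seen in these cells, and a plain phenyl serves as a simple reference point for judging other groups there, though nothing at hand explains why the two compounds read alike.

As far as these compounds go, what remains open is whether a very different group at this same place, such as an amine or a carboxylic acid, would move the number beyond the scatter from that of the plain phenyl. From the compounds shown here alone, it is also open whether the same swap of chloro for hydrogen on the two chlorophenyl groups of the shared core would prove just as small.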